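Fluoro to bromo in the antiproliferative series

The source may report more compounds than this note shows. Statements on the series, on what has been measured and on what is new or still open speak of the compounds shown alone.

Going by the values given here, in a functional assay on CCRF-CEM cells (Homo sapiens) for antiproliferative activity, read by cell counting, with a stated time of 72 h (on this read-out lower numbers stand for stronger inhibition and higher numbers for weaker inhibition), compound 2 (`C#C[C@@]1(O)[C@@H](CO)O[C@@H](n2cc(F)c3c(N)ncnc32)[C@@H]1O`) gives 160 nM, the only actual number so far. Compound 1 (`C#C[C@@]1(O)[C@@H](CO)O[C@@H](n2cnc3c(-c4ccccc4)ncnc32)[C@@H]1O`) reads > 250000 nM, which is a limit of the assay. Compound 3 (`C#C[C@@]1(O)[C@@H](CO)O[C@@H](n2cc(Br)c3c(N)ncnc32)[C@@H]1O`) carries bromo in place of fluoro on an aromatic carbon. Among the compounds with values here, no measured step covers this exchange. In this assay a small step of uncertain direction is expected, possibly none beyond the scatter. The estimated change is a 1.2-fold lower number from compound 2 to compound 3 (0.09 log units; within the scatter). For compound 3 the expected value is 130 nM, with an estimated range of 30 nM to 600 nM.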

Compound 3, half-maximal inhibitory concentration: 30 nM
Compound 3: middle estimate off by 4.3-fold (0.64 log units), on the high side; the range from low to high includes it.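

In this assay, bromo in place of fluoro on an aromatic carbon gives a 5.3-fold lower number from compound 2 to compound 3 (0.73 log units; beyond the scatter), the only step shown between compounds that differ in one place. Going by these compounds alone, the number at this carbon of the five-membered aromatic ring therefore depends on which of these two groups it carries, which the earlier compounds could not show.

From the compounds shown here alone, whether chloro, an amine or a longer chain would lower the number further at this carbon stays open. Nothing shown bears on why the exchange gives a step of this size.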